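Benzyloxy for pyrimidinyl on the sulfonamide aryl ring

A few compounds are considered here, and "the series" means these few. Any claim that something is new, unique, unknown or untested is made for them only; others in the source may bear on it.

Measured so far:
- compound 1 `C[C@@H]1CN(c2ccc(Cl)c(NS(=O)(=O)c3ccc(-c4ccccn4)s3)c2)C[C@H](C)N1` gives 39.8 nM in a functional assay for agonist activity at growth hormone secretagogue receptor type 1 (Homo sapiens), read by FLIPR; on this read-out higher numbers stand for an effect only at larger amounts of compound and lower numbers for an effect already at smaller amounts
- compound 2 `COc1ccc(N2C[C@@H](C)N[C@@H](C)C2)cc1NS(=O)(=O)c1ccc(-c2cncnc2)cc1` gives 316 nM in this assay

Of the two numbers, compound 2 stands at the higher one, and its gap to compound 1 lies beyond the usual scatter. Compound 3 `COc1ccc(N2C[C@@H](C)N[C@@H](C)C2)cc1NS(=O)(=O)c1ccc(OCc2ccccc2)cc1` differs from compound 2 in one place: benzyloxy in place of pyrimidin-5-yl on an aromatic carbon. No comparable exchange has been measured in this set, so the direction of the step is open. Compound 3 is expected to land near compound 2, with a step of a 1.3-fold lower number from compound 2 to compound 3 (0.10 log units; within the scatter) that could fall either side of the scatter. The estimate for compound 3 is 250 nM, within 60 nM to 1000 nM.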

Compound 3, half-maximal effective concentration: 100 nM
Estimate against measurement, compound 3: 2.5-fold (0.40 log units) above; the range from low to high includes it.
By their numbers in this assay, from the lowest: compound 1; then compound 3; then compound 2.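

In this assay, benzyloxy in place of pyrimidin-5-yl gives a 3.2-fold lower number from compound 2 to compound 3 (0.50 log units; beyond the scatter), so the group on this aromatic carbon does affect the read-out, and the carbon-only ring with its oxygen-containing link is accepted here in place of the two-nitrogen ring. Nothing measured here accounts for the step. From the compounds shown here alone, whether the oxygen link or the ring itself matters stays open: plain phenyl, or benzylamino with nitrogen in place of the oxygen, would separate them. Compound 1 differs from both in more than one place and gives no reading on this change.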